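Amide nitrogen variation on the hydroxamate oxadiazole series

A few compounds are considered here, and "the series" means these few. Any claim that something is new, unique, unknown or untested is made for them only; others in the source may bear on it.

The three measured compounds share one core and differ only in the group on the carbonyl carbon attached to the aromatic ring. Compound 1 `CNC(=O)c1noc([C@H](CCCC2CCCCC2)CC(=O)NO)n1` carries a methylamino group and in an assay on CHO cells for inhibition of bone morphogenetic protein 1 (Homo sapiens), read by fluorescence (on this read-out lower numbers stand for stronger inhibition and higher numbers for weaker inhibition), gives 28 nM. Compound 2 `O=C(O)CNC(=O)c1noc([C@H](CCCC2CCCCC2)CC(=O)NO)n1` adds a carboxy group on the chain carbon bound to the amide nitrogen and gives 21 nM, a shift of a 1.3-fold lower number from compound 1 to compound 2 (0.12 log units; within the scatter). Compound 3 `O=C(C[C@@H](CCCC1CCCCC1)c1nc(C(=O)N2CCCC2)no1)NO` closes the nitrogen into a pyrrolidin-1-yl ring and gives 43 nM; the step of a 1.5-fold higher number from compound 1 to compound 3 (0.19 log units; within the scatter) is within the scatter, while a 2.0-fold higher number from compound 2 to compound 3 (0.31 log units; beyond the scatter) is modest but beyond it. Compound 3 thus sits at the weaker-looking end of a narrow spread.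

Compound 4 `O=C(C[C@@H](CCCC1CCCCC1)c1nc(C(=O)N2CCCCC2)no1)NO` differs from compound 3 by piperidin-1-yl in place of pyrrolidin-1-yl on a carbonyl carbon. Going by the values given here, no measured pair covers a ring enlargement at this position; the two steps that bear on it, a 1.5-fold higher number from compound 1 to compound 3 (0.19 log units; within the scatter) and a 2.0-fold higher number from compound 2 to compound 3 (0.31 log units; beyond the scatter), show that exchanging the group on this carbonyl carbon moves the number only a little. A step within the scatter is therefore expected, with no clear direction.

The estimate for compound 4 is 45 nM, with a range of 20 nM to 110 nM, corresponding to an expected step of a 1.0-fold higher number from compound 3 to compound 4 (0.02 log units; within the scatter).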

Compound 4, half-maximal inhibitory concentration: 26 nM
Estimate against measurement, compound 4: 1.7-fold (0.24 log units) above; low and high end bracket the measured number.
By their numbers in this assay, from the lowest: compounds 2, 4, 1 and 3 (each within the scatter of the next, the first and the last beyond it).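

Notes on the ring size at the carbonyl carbon: in this assay, enlarging pyrrolidin-1-yl to piperidin-1-yl gives a 1.7-fold lower number from compound 3 to compound 4 (0.22 log units; within the scatter), so this first change of ring size at the position does not separate the two ring amides. The piperidin-1-yl group also cannot be told apart from either open-chain group, with a 1.1-fold lower number from compound 1 to compound 4 (0.03 log units; within the scatter) and a 1.2-fold higher number from compound 2 to compound 4 (0.09 log units; within the scatter). Going by these compounds alone, the one step beyond the scatter so far, a 2.0-fold higher number from compound 2 to compound 3 (0.31 log units; beyond the scatter), therefore does not carry over to every ring amide, since the piperidin-1-yl compound 4 stays within the scatter of compound 2, and the series remains flat across all four groups on this carbonyl carbon.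

No measurement on hand offers an explanation for these values.

Still open, as far as these compounds go, is whether a ring holding a second hetero atom, such as morpholin-4-yl or piperazin-1-yl, would stay within this narrow band. Equally open, from the compounds shown here alone, is how a carboxylic acid or a primary amine carried on the piperidin-1-yl ring would compare with the open-chain carboxy group of compound 2.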